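A few compounds are considered here, and "the series" means these few. Any claim that something is new, unique, unknown or untested is made for them only; others in the source may bear on it.

Cytotoxicity in a functional assay on A-431 cells (Homo sapiens) for cytotoxicity, read by MTT assay, with a stated time of 24 h (a lower number here means a stronger inhibitor, a higher number a weaker inhibitor), for the measured compounds:

Compound 1 `CC1=C([Se]CC(OC(=O)[C@@H](CO)NC(=O)OC(C)(C)C)C(=O)NCCCCCC(=O)OCc2ccccc2)C(=O)c2ccccc2C1=O`: 4000 nM
Compound 2 `CC1=C(SCCC(=O)OC(C[Se]c2ccccc2)C(=O)NCCCCCC(=O)OCc2ccccc2)C(=O)c2ccccc2C1=O`: a limit of the assay, > 100000 nM
Compound 3 `CC1=C(SCCC(=O)OC(CC[Se]c2ccccc2)C(=O)NC(C)(C)C)C(=O)c2ccccc2C1=O`: a limit of the assay, > 100000 nM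

Among the compounds with values here, compound 1 is the only member of the series with a number in this assay; compounds 2 and 3 sit at the limit of > 100000 nM in this assay, at which 2 of the 3 values shown sit, and give no number. Within the data shown here, neither of them differs from compound 1 in a single place, so no measured step is available.

Compound 4 `CC1=C([Se]CC(OC(=O)CC[Se]c2ccccc2)C(=O)NCCCCCC(=O)OCc2ccccc2)C(=O)c2ccccc2C1=O` is not yet measured. It differs from compound 1 by a group of 9 heavy atoms (8 carbon, 1 selenium; one six-membered aromatic ring of carbon only) in place of a group of 11 heavy atoms (7 carbon, 1 nitrogen, 3 oxygen; no ring), on a carbonyl carbon. The entering group carries a phenylselanyl unit of the kind present in compounds 2 and 3, both of which sit at the limit of > 100000 nM in this assay, at which 2 of the 3 values shown sit; the carbamate and hydroxyl of compound 1 are lost. On that basis the step from compound 1 to compound 4 in this assay is expected to weaken, modestly, by about a 2.0-fold higher number from compound 1 to compound 4 (0.30 log units; within the scatter). Compound 4 is therefore estimated at 8000 nM, within 1500 nM to 40000 nM.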

Compound 4, half-maximal inhibitory concentration: 4000 nM
The estimate for compound 4 lay 2.0-fold (0.30 log units) above the measured number; the range from low to high includes it.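

In this assay, placing the phenylselanyl-bearing group on this carbonyl carbon in place of 2-hydroxy-1-((tert-butoxycarbonyl)amino)ethyl gives no change at the digits printed from compound 1 to compound 4 (within the scatter). A measured value at this position therefore does not depend on the carbamate and hydroxyl of compound 1, and a phenylselanyl unit does not by itself go with a limit of the assay. Compounds 2 and 3 remain limits of the assay, and no step to them can be read: the limit of > 100000 nM in this assay, at which 2 of the 4 values shown sit.

Within the data shown here, no pair isolates selenium against sulfur on the shared core. As far as these compounds go, what an amine or a carboxylic acid on this carbonyl carbon would give also remains open.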